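The source may report more compounds than this note shows. Statements on the series, on what has been measured and on what is new or still open speak of the compounds shown alone.

The series shares one core and varies the aryl group on it. Compound 1 `Cc1cc(C)cc(-c2cnc(Nc3ccc(C#N)cc3)nc2Oc2c(C)cc(C#N)cc2C)c1` gives 39000 nM in an ADME assay on MT4 cells (Homo sapiens) for cytotoxicity, read by MTT assay, with a stated time of 5 days; on this read-out lower numbers stand for higher toxicity in this test and higher numbers for lower toxicity in this test. Compound 2 `Cc1cc(C#N)cc(C)c1Oc1nc(Nc2ccc(C#N)cc2)ncc1-c1ccc(N)cc1` gives 310 nM, and compound 3 `Cc1cc(C#N)cc(C)c1Oc1nc(Nc2ccc(C#N)cc2)ncc1-c1ccccc1` gives 31800 nM. Compound 3 thus stands second highest of the three; its gap to compound 1 is small, a 1.2-fold lower number from compound 1 to compound 3 (0.09 log units; within the scatter), while its gap to compound 2 is large, a 100-fold higher number from compound 2 to compound 3 (2.01 log units; beyond the scatter).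

Compound 4 `Cc1cc(C#N)cc(C)c1Oc1nc(Nc2ccc(C#N)cc2)ncc1-c1ccc(C(F)(F)F)cc1` differs from compound 3 by trifluoromethyl in place of hydrogen on an aromatic carbon. Among the measured compounds shown here, two steps touch the same ring: the methyls of compound 1 hardly moved the number, whereas removing the amino of compound 2 shifted it by a large step. Neither is a close match for a trifluoromethyl group, so the direction is uncertain and a small step is the more likely. Compound 4 is therefore expected to sit near compound 3, with a 1.3-fold lower number from compound 3 to compound 4 (0.10 log units; within the scatter) as the estimated step, and an estimated value of 25000 nM, within a range from 8000 nM to 60000 nM.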

Compound 4, half-maximal cytotoxic concentration: 35000 nM
Beside the measured number, compound 4's estimate is 1.4-fold (0.15 log units) below it, and the stated range covers the measured number.
By their numbers in this assay, from the lowest: compound 2; then compounds 3, 4 and 1 (each within the scatter of the next).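

In this assay, trifluoromethyl on the carbon para to a large group leaves the number where the unsubstituted phenyl had it (a 1.1-fold higher number from compound 3 to compound 4 (0.04 log units; within the scatter)), so a substituent of several heavy atoms at this place need not shift it. Amino remains the one group shown here that goes with a large shift: trifluoromethyl in its place gives a large step (a 110-fold higher number from compound 2 to compound 4 (2.05 log units; beyond the scatter)), whereas 4-(trifluoromethyl)phenyl in place of 3,5-dimethylphenyl gives a step within the scatter (a 1.1-fold lower number from compound 1 to compound 4 (0.05 log units; within the scatter)). No measurement given here bears on the reason for this result.

From the compounds shown here alone, whether the large step belongs to amino alone stays open, and a hydroxyl, a methylamino or an acetamido group at the same place would test that. Also open, going by these compounds, is whether a carboxylic acid or a longer chain there would keep the number or move it.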